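From methyl to ethoxy on compound 1

A few compounds are considered here, and "the series" means these few. Any claim that something is new, unique, unknown or untested is made for them only; others in the source may bear on it.

Measured so far in a functional assay on MCF7 cells (Homo sapiens) for antiproliferative activity; a lower number here means a stronger inhibitor of growth, a higher number a weaker inhibitor of growth
compound 1 (`COc1ccc(-c2nc3cc(F)ccc3s2)cc1C`) 48 nM
compound 2 (`COc1cc(OC)cc(-c2nc3cc(F)ccc3s2)c1`) 1230 nM
compound 3 (`COc1cc(-c2nc3cc(F)ccc3s2)cc(O)c1OC`) 653 nM

In this assay compound 1 has the lowest number of the three, and compounds 2 and 3 both lie above it by more than the scatter. Compound 4 (`CCOc1cc(-c2nc3cc(F)ccc3s2)ccc1OC`) carries ethoxy in place of methyl on an aromatic carbon of compound 1, ortho to a methoxy group (ethoxy in place of methyl on an aromatic carbon). Among the measured compounds shown here, no measured pair isolates this change. Neither compound 3 (653 nM) nor compound 2 (1230 nM) has the methyl, so a move to a higher number is expected, though probably a smaller one than those gaps. The expected step is a 3.1-fold higher number from compound 1 to compound 4 (0.49 log units; beyond the scatter) in this assay and is uncertain. The estimated value for compound 4 is 150 nM (range 30 nM to 700 nM).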

Compound 4, concentration for 50% growth inhibition: 80 nM
Estimate against measurement, compound 4: 1.9-fold (0.27 log units) above, and the stated range covers the measured number.
By their numbers in this assay, from the lowest: compounds 1 and 4 (each within the scatter of the next); then compounds 3 and 2 (each within the scatter of the next).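

In this assay, ethoxy in place of methyl on this aromatic carbon, ortho to a methoxy group, gives a 1.7-fold higher number from compound 1 to compound 4 (0.22 log units; within the scatter). Among the compounds shown here, this is the first pair to isolate a single change at this position, which accepts the 3 heavy atoms of ethoxy against the 1 of methyl with no step beyond the scatter. No measurement available here bears on the cause of this result. On these data alone, whether this tolerance extends to a longer chain such as butoxy, or to an amine or a carboxylic acid at this position, remains open.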